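The source may hold more compounds than are shown below. What is called first, only, known or untested is meant among the compounds shown, and "the series" means these compounds.

Three compounds have numbers in a functional assay for inhibition, with Homo sapiens as the target; a higher number here means a weaker inhibitor, a lower number a stronger inhibitor. Compound 1 `COc1ccc(Nc2nccc(-c3cccs3)n2)cc1` gives 3900 nM, compound 2 `Cc1cc(-c2ccccn2)nc(Nc2ccc(N(C)C)cc2)n1` gives 31900 nM, and compound 3 `Cc1ccsc1-c1ccnc(Nc2ccc(N(C)C)cc2)n1` gives 1800 nM, the lowest of the three. Its nearest neighbour is compound 1, whose number lies beyond the scatter above it, and compound 2 lies far higher still. Compound 4 `CN(C)c1ccc(Nc2nccc(-c3cccs3)n2)cc1` has not been measured in this assay. It differs from compound 3 in one place: hydrogen in place of methyl on an aromatic carbon. The same thiophen-2-yl is carried by compound 4 and by compound 1, which gives 3900 nM, above compound 3. A modest rise is therefore expected, a 1.7-fold higher number from compound 3 to compound 4 (0.22 log units; within the scatter), perhaps within the scatter. Compound 4 is expected to give about 3000 nM in this assay, within 1200 nM to 7500 nM.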

Compound 4, half-maximal inhibitory concentration: 900 nM
Beside the measured number, compound 4's estimate is 3.3-fold (0.52 log units) above it; measured number below the stated range.
By their numbers in this assay, from the lowest: compounds 4 and 3 (each within the scatter of the next); then compound 1; then compound 2.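

In this assay, the step with hydrogen in place of methyl on this aromatic carbon, a 2.0-fold lower number from compound 3 to compound 4 (0.30 log units; within the scatter), shows that compounds with the 3-methylthiophen-2-yl and thiophen-2-yl groups cannot be told apart, so the methyl is not needed to keep this level. With thiophen-2-yl held constant, dimethylamino in place of methoxy gives a step beyond the scatter, a 4.3-fold lower number from compound 1 to compound 4 (0.64 log units; beyond the scatter). Nothing available accounts for either step. The compounds shown leave open how a chlorine or an ethyl group on that same carbon would read, and whether a morpholine in place of dimethylamino would hold the number of compound 4.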